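Swapping a Phenyl for a 4-Methylbenzyl on the Core

A few compounds are considered here, and "the series" means these few. Any claim that something is new, unique, unknown or untested is made for them only; others in the source may bear on it.

Measured so far in an in vitro functional assay on cells for agonist activity at Bombesin receptor subtype-3 (Mus musculus), read by luminescence and calcium flux; on this read-out lower numbers stand for an effect already at smaller amounts and higher numbers for an effect only at larger amounts of compound:
Compound 1 `N#Cc1ccc(Cc2cnc(CCc3ccc(-c4ccccc4C(=O)O)cc3)[nH]2)cc1`: compound 1 gives 723 nM.
Compound 2 `O=C(O)c1ccccc1-c1ccc(CCc2ncc(Cc3cccc(F)c3)[nH]2)cc1`: compound 2 gives 7.9 nM.
Compound 3 `O=C(O)c1ccccc1-c1ccc(CCc2ncc(-c3ccccc3)[nH]2)cc1`: compound 3 gives 872 nM.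

Compound 3 sits at the high end of these three numbers. One step, a 1.2-fold higher number from compound 1 to compound 3 (0.08 log units; within the scatter), is within the scatter, while the other, a 110-fold higher number from compound 2 to compound 3 (2.04 log units; beyond the scatter), is a large step.

The new compound 4 `Cc1ccc(Cc2cnc(CCc3ccc(-c4ccccc4C(=O)O)cc3)[nH]2)cc1` differs from compound 3 by 4-methylbenzyl in place of phenyl on an aromatic carbon. For the measured compounds named here, two measured steps bear on this. Going from compound 1 to compound 3 changed a 4-cyanobenzyl into a phenyl at this carbon and gave a 1.2-fold higher number from compound 1 to compound 3 (0.08 log units; within the scatter), so a benzyl group carrying a group on its far ring carbon did not move the number beyond the scatter. Going from compound 2 to compound 3 changed a 3-fluorobenzyl into a phenyl and gave a 110-fold higher number from compound 2 to compound 3 (2.04 log units; beyond the scatter), so a benzyl group can lower the number a great deal. A 4-methylbenzyl resembles the first case more than the second, yet the methyl is not the nitrile. A modest downward step is expected, a 3.5-fold lower number from compound 3 to compound 4 (0.54 log units; beyond the scatter), though with wide uncertainty. Compound 4 is therefore estimated at 250 nM, within the range 30 nM to 1500 nM.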

Compound 4, half-maximal effective concentration: 162 nM
The estimate for compound 4 lay 1.5-fold (0.19 log units) above the measured number; low and high end bracket the measured number.
By their numbers in this assay, from the lowest: compound 2; then compound 4; then compounds 1 and 3 (each within the scatter of the next).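

In this assay, a 4-methylbenzyl at this carbon of the five-membered ring does better than the plain phenyl (a 5.4-fold lower number from compound 3 to compound 4 (0.73 log units; beyond the scatter)), so a group with a substituent at the 4-position of its benzyl ring need not leave the number where compound 1 had suggested. The substituent on that benzyl ring matters too: with the rest of the molecule unchanged, methyl in place of the nitrile gives a clear drop (a 4.5-fold lower number from compound 1 to compound 4 (0.65 log units; beyond the scatter)). Even so, the benzyl link plus a small group is not enough to reach the low number of compound 2, as the change from 3-fluorophenyl to 4-methylphenyl on the chain carbon shows a large rise (a 21-fold higher number from compound 2 to compound 4 (1.31 log units; beyond the scatter)).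

That last step changes both the atom on the ring and its place, so a 4-fluorobenzyl or a 3-methylbenzyl would be needed to tell which of the two counts for more. Nothing in hand explains why any of these groups shifts the number as it does.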